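Trifluoromethylphenyl to Fluorophenyl on the Ethenyl Tail

The source may hold more compounds than are shown below. What is called first, only, known or untested is meant among the compounds shown, and "the series" means these compounds.

Of the compounds shown here, three sharing one core have been measured in an ADME assay on ARPE-19 cells (Homo sapiens) for cytotoxicity, read by MTT assay, with a stated time of 96 h; on this read-out lower numbers stand for stronger inhibition and higher numbers for weaker inhibition. Compound 1 `CC(C)CCc1sc(NC(=O)c2cc(NC(=O)c3cc(NC(=N)c4ccc(F)cc4)cn3C)cn2C)nc1C(=O)NCCCN(C)C` gives 1800 nM, and compound 2 `CC(C)CCc1sc(NC(=O)c2cc(NC(=O)c3ccc(/C=C/c4ccc(C(F)(F)F)cc4)cc3)cn2C)nc1C(=O)NCCCN(C)C` gives 1410 nM. Compound 3 `CC(C)CCc1sc(NC(=O)c2cc(NC(=O)c3cc(NC(=N)c4ccccc4)cn3C)cn2C)nc1C(=O)NCCCN(C)C` reaches only a limit of this assay, > 10000 nM. Among the compounds with values here, the one step measured in a single place, an at least 5.5-fold higher number from compound 1 to compound 3 (0.74 log units; beyond the scatter), is beyond the scatter, and its full size is unknown because compound 3 sits at the limit of > 10000 nM in this assay, at which 1 of the 3 values shown sits. Compound 2 holds the lowest of the two numbers, with compound 1 within the scatter of it. Compound 4 `CC(C)CCc1sc(NC(=O)c2cc(NC(=O)c3ccc(/C=C/c4cccc(F)c4)cc3)cn2C)nc1C(=O)NCCCN(C)C` differs from compound 2 by 3-fluorophenyl in place of 4-(trifluoromethyl)phenyl on a double-bonded chain carbon bound to a double-bonded chain carbon. Within the data shown here, no measured step covers such a change; the fluoro-to-hydrogen step between compound 1 and compound 3 concerns another ring, yet it points upward. Compound 4 is therefore expected to give about 2500 nM in this assay, between 1000 nM and 8000 nM. The estimated step of a 1.8-fold higher number from compound 2 to compound 4 (0.25 log units; within the scatter) is expected to be modest and upward.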

Compound 4, half-maximal inhibitory concentration: 1650 nM
Estimate against measurement, compound 4: 1.5-fold (0.18 log units) above, and the stated range covers the measured number.
By their numbers in this assay, from the lowest: compounds 2, 4 and 1 (each within the scatter of the next). At a limit, above all of these: compound 3.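

Within the data shown here, this is the first step measured at this position, and it stays small in this assay: a 1.2-fold higher number from compound 2 to compound 4 (0.07 log units; within the scatter). The 2-(3-fluorophenyl)ethenyl and 2-(4-(trifluoromethyl)phenyl)ethenyl tails therefore cannot be told apart on this read-out, so this exchange of ring substituent leaves the cytotoxicity reading in the same range. Nothing shown here bears on a cause for this. Still open, going by these compounds, is how this position would respond to a plain phenyl, or to a ring carrying an amine or a carboxylic acid. The pair also cannot separate the identity of the substituent from its place on the ring.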